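Swapping the core aryl substituent: from phenethyl to fluorophenoxy

The source may report more compounds than this note shows. Statements on the series, on what has been measured and on what is new or still open speak of the compounds shown alone.

Compound 1 `COc1ccc(F)cc1CNCCCNc1ccnc2cc(CCc3ccccc3)ccc12` gives 23 10^-6 cm/s in an ADME assay for permeability, using PAMPA, with a stated time of 30 min, at pH 7.4; on this read-out higher numbers stand for higher permeability and lower numbers for lower permeability.
Compound 2 `COc1ccc(-c2ccc3c(NCCCNCc4ccco4)ccnc3c2)cc1` gives 237 10^-6 cm/s in this assay.
Compound 3 `c1ccc(CCc2ccc3c(NCCCNCc4ccco4)ccnc3c2)cc1` gives 23 10^-6 cm/s in this assay.

Compound 1 stands level with compound 3 at the digits shown, the two together being the lowest of the three numbers, while compound 2 sits a large gap above them. The step of no change at the digits printed from compound 1 to compound 3 (within the scatter) shows that the group on the amine side leaves the read-out unchanged, whereas the step of a 10-fold lower number from compound 2 to compound 3 (1.01 log units; beyond the scatter) shows that the group on the aromatic carbon of the core moves it strongly. Compound 4 `COc1ccc(F)cc1CNCCCNc1ccnc2cc(Oc3ccc(F)cc3)ccc12` differs from compound 1 by 4-fluorophenoxy in place of phenethyl on an aromatic carbon. Since this is the same position where a 10-fold lower number from compound 2 to compound 3 (1.01 log units; beyond the scatter) was seen, a sizeable move is expected, most likely upward, though a drop cannot be excluded. Compound 4 is therefore estimated at 60 10^-6 cm/s, with a range of 15 10^-6 cm/s to 200 10^-6 cm/s, which means an expected step of a 2.6-fold higher number from compound 1 to compound 4 (0.42 log units; beyond the scatter).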

Compound 4, apparent permeability: 317 10^-6 cm/s
Beside the measured number, compound 4's estimate is 5.3-fold (0.72 log units) below it; measured number above the stated range.
By their numbers in this assay, from the lowest: compounds 1 and 3 (each within the scatter of the next); then compounds 2 and 4 (each within the scatter of the next).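

In this assay, replacing phenethyl with 4-fluorophenoxy gives a 14-fold higher number from compound 1 to compound 4 (1.14 log units; beyond the scatter) with the 5-fluoro-2-methoxyphenyl group on the amine side. Until now this position had moved the read-out only in the furan-2-yl compounds, so the large effect of changing this aromatic-carbon substituent now also appears with a second amine-side group. The entering group keeps the heavy-atom count of phenethyl but adds one hydrogen-bond acceptor.

Whether the oxygen or the fluorine accounts for the step remains open, and an unsubstituted phenoxy or a benzyloxy group at this carbon would help separate them. Nothing available explains the step.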